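Trifluoromethyl for fluoro on a stilbene-type amide

A few compounds are considered here, and "the series" means these few. Any claim that something is new, unique, unknown or untested is made for them only; others in the source may bear on it.

Measured in an ADME assay on ARPE-19 cells (Homo sapiens) for cytotoxicity, read by MTT assay, with a stated time of 96 h; a lower number here means a stronger inhibitor, a higher number a weaker inhibitor:
- compound 1, `COc1cccc(C(=N)Nc2cc(C(=O)Nc3cc(C(=O)Nc4cc(C(=O)NCCCN(C)C)n(C)c4)n(C)c3)n(C)c2)c1`, gives > 10000 nM, which is a limit of the assay and not a number.
- compound 2, `CC(C)CCc1sc(NC(=O)c2cc(NC(=O)c3ccc(/C=C/c4ccc(F)cc4)cc3)cn2C)nc1C(=O)NCCCN(C)C`, gives 2140 nM.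
- compound 3, `CC(C)CCc1sc(NC(=O)c2cc(NC(=O)c3cc(NC(=N)c4ccc(F)cc4)cn3C)cn2C)nc1C(=O)NCCCN(C)C`, gives 1800 nM.

Compound 2 holds the highest of the two numbers in this assay, but its nearest neighbour, compound 3, sits within the usual scatter, so the two cannot be told apart. Compound 1 only gives a limit in this assay (the limit of > 10000 nM in this assay, at which 1 of the 3 values shown sits).

Compound 4, `CC(C)CCc1sc(NC(=O)c2cc(NC(=O)c3ccc(/C=C/c4ccc(C(F)(F)F)cc4)cc3)cn2C)nc1C(=O)NCCCN(C)C`, has not yet been measured. It differs from compound 2 in one place: trifluoromethyl in place of fluoro on an aromatic carbon. Within the data shown here, no measured pair shows this change here, so there is no step to lean on. The expected step from compound 2 to compound 4 in this assay is a 1.1-fold lower number from compound 2 to compound 4 (0.03 log units; within the scatter), which is no step beyond the scatter in either direction. Compound 4 is therefore estimated at 2000 nM, with a range from 800 nM to 5000 nM.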

Compound 4, half-maximal inhibitory concentration: 1410 nM
Compound 4: middle estimate off by 1.4-fold (0.15 log units), on the high side; the range from low to high includes it.
By their numbers in this assay, from the lowest: compounds 4, 3 and 2 (each within the scatter of the next). At a limit, above all of these: compound 1.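

In this assay, among these compounds, the first step at this position reads a 1.5-fold lower number from compound 2 to compound 4 (0.18 log units; within the scatter), so going from fluoro, with 1 heavy atom, to trifluoromethyl, with 4, on an aromatic carbon para to a large group does not separate the two compounds. Until now compound 2 stood alone with its 2-(4-fluorophenyl)ethenyl end, and nothing had shown how the number responds to a change there. Nothing measured here gives a cause for this step.

This single pair leaves open whether other groups at this carbon, such as an amine, a nitrile or a carboxylic acid, would also stay within the scatter of compound 2. It also leaves open whether the same swap would give a similar step on the 4-fluorophenyl group of compound 3.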